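Replacing one side group on compound 3

This account rests on a few compounds, and the source may have more. Where it says the series, first, only, none or still open, it means among the compounds named here.

Measured in a functional assay on PC-3 cells (Homo sapiens), read by MTT assay, with a stated time of 48 h; on this read-out higher numbers stand for weaker inhibition and lower numbers for stronger inhibition:
- Compound 1 `CCN(CC)CCCNC(=O)c1ccc(C(CC)(CC)c2ccc(OCC(=O)C(C)(C)C)c(C)c2)n1CC` gives 1800 nM
- Compound 2 `CCn1c(C(=O)NCCN(C)C)ccc1C(CC)(CC)c1ccc(OCC(O)C(C)(C)C)c(C)c1` gives 1630 nM
- Compound 3 `CCN(CC)CCCNC(=O)c1ccc(C(CC)(CC)c2ccc(OCC(O)C(C)(C)C)c(C)c2)n1CC` gives 2500 nM

Compound 3 has the highest of these three numbers, but it cannot be separated from the other two, since both gaps lie within the scatter. Compound 4 `CCn1c(C(=O)N(CCC#N)CCC#N)ccc1C(CC)(CC)c1ccc(OCC(O)C(C)(C)C)c(C)c1` has not yet been measured. It differs from compound 3 in one place: a group of 9 heavy atoms (6 carbon, 3 nitrogen; no ring) in place of a group of 9 heavy atoms (7 carbon, 2 nitrogen; no ring), on a carbonyl carbon.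

Two measured steps offer some guidance. The closer one alters the same side group, with (diethylamino)methyl in place of dimethylamino, and shows a 1.5-fold higher number from compound 2 to compound 3 (0.19 log units; within the scatter). The other exchanges 1-hydroxy-2,2-dimethylpropyl for (tert-butyl)carbonyl elsewhere in the molecule and shows a 1.4-fold higher number from compound 1 to compound 3 (0.14 log units; within the scatter). Among the compounds with values here, no measured compound carries the entering group, so these steps are only a weak guide, and the range must stay wide.

In this assay no change beyond the scatter is expected. The expected step is a 1.2-fold higher number from compound 3 to compound 4 (0.08 log units; within the scatter). The estimate for compound 4 is 3000 nM, with an expected range from 1000 nM to 9000 nM.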

Compound 4, half-maximal inhibitory concentration: 7800 nM
Compound 4: middle estimate off by 2.6-fold (0.41 log units), on the low side, and the stated range covers the measured number.
By their numbers in this assay, from the lowest: compounds 2, 1 and 3 (each within the scatter of the next); then compound 4.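

Within the data shown here, exchanging the (3-(diethylamino)propyl)amino group for one with triple bonds and 0 hydrogen-bond donors gives the first steps beyond the scatter in this assay, with a 3.1-fold higher number from compound 3 to compound 4 (0.49 log units; beyond the scatter) and a 4.8-fold higher number from compound 2 to compound 4 (0.68 log units; beyond the scatter) as the two readings. The group on this carbonyl carbon therefore does affect the number, and both modest steps point towards weaker inhibition, whereas the earlier change between the dimethylamino and (diethylamino)methyl chain ends stayed within the scatter. Nothing available here explains why this exchange weakens inhibition.

The entering group differs from the leaving group in both its chains and its lack of an amide hydrogen, so the compounds shown cannot tell which of these differences matters. An amide that keeps its hydrogen and carries one 2-cyanoethyl chain would help to separate them.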